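Benzyl ester in place of the serine hydroxy group

A few compounds are considered here, and "the series" means these few. Any claim that something is new, unique, unknown or untested is made for them only; others in the source may bear on it.

Two compounds of the series carry a number in a functional assay on the whole organism (Tail, strain ICR) with Mus musculus as the target, in the tail flick test, with a stated time of 120 min, at a dose of 25 umol/kg by the oral route; a lower number here means a weaker effect, a higher number a stronger effect of the compound at the dose given. Compound 1 `O=C(CN(c1nc(Cl)nc2[nH]cnc12)C1CC1)N[C@@H](CO)C(=O)OCc1ccccc1` gives 34.5% and stands highest of the two. Among the measured compounds shown here, compound 2 `O=C(CN(c1ncnc2c1ncn2C1CCCCO1)C1CC1)N[C@@H](CCC(=O)OCc1ccccc1)C(=O)OCc1ccccc1`, built on a different core, gives 20.7%, a value lying beyond the scatter below compound 1; no single-point step links these two, so the pair is read only as two values.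

Compound 3 `O=C(CN(c1nc(Cl)nc2[nH]cnc12)C1CC1)N[C@@H](CC(=O)OCc1ccccc1)C(=O)OCc1ccccc1` is the unmeasured member. Relative to compound 1 it differs as follows: benzyloxycarbonyl in place of hydroxy on a saturated chain carbon, two bonds along the chain from an amide-type nitrogen and a carbonyl carbon. For the measured compounds named here, no measured pair isolates this change, so the direction of the step is not fixed by the data. Taking the lower value of the other benzyl-ester-bearing member, compound 2, as loose guidance, a modest downward step from compound 1 to compound 3 of about a number 7.5 percentage points lower from compound 1 to compound 3 (within the scatter) is expected, near the edge of the scatter. Compound 3 is estimated at 27% in this assay, within a range of 12% to 44%.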

Compound 3, a percentage reported as activity, at one dose (the size of the read-out at that dose, not a potency): 12.1%
For compound 3 the middle estimate is 14.9 percentage points above the measured one, and the stated range covers the measured number.
By their numbers in this assay, from the lowest: compounds 3 and 2 (each within the scatter of the next); then compound 1.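

In this assay, the series now has its first step that changes one place only: benzyloxycarbonyl in place of hydroxy on a saturated chain carbon, two bonds along the chain from an amide-type nitrogen and a carbonyl carbon, gives a number 22.4 percentage points lower from compound 1 to compound 3 (beyond the scatter). This position is therefore not indifferent to the exchange, and on the shared core the step runs downward, beyond the scatter. Among the compounds shown here, no supporting data bear on the origin of this step, and the single exchange does not separate the loss of the hydroxy from the arrival of the benzyloxycarbonyl.

Open, going by these compounds, is whether a carboxylic acid, a primary amine or a methyl ester at this place would stay near compound 1 or near compound 3. Also open, on these data alone, is whether the same exchange gives a similar step on the core of compound 2.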